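The compounds below may be only part of what the source reports. "The series", "measured", "known", "first", "only" and "open" are said of these compounds alone.

Measured compounds:
- compound 1 `O=C(N/N=C/c1cccc(Cl)c1)c1cccnc1Nc1cccc(C(F)(F)F)c1`: in a functional assay on the whole organism (strain Wistar) for inhibition, with Rattus norvegicus as the target, read by paw edema, with a stated time of 30 min, at a dose of 10 mg/kg by the intraperitoneal route (on this read-out lower numbers stand for less inhibition and higher numbers for more inhibition at the one dose given (going by the name of the read-out)), compound 1 gives 77.8%
- compound 2 `O=C(N/N=C/c1ccc(O)cc1)c1cccnc1Nc1cccc(C(F)(F)F)c1`: compound 2 gives 59.3%
- compound 3 `CN(C)c1ccc(/C=N/NC(=O)c2cccnc2Nc2cccc(C(F)(F)F)c2)cc1`: compound 3 gives 61.3%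

Compound 2 stands lowest of the three on paw edema inhibition, though its nearest neighbour is compound 3, which lies within the scatter of it a number 2 percentage points higher from compound 2 to compound 3 (within the scatter). The gap to compound 1 is larger and beyond the scatter a number 18.5 percentage points lower from compound 1 to compound 2 (beyond the scatter). The parallel step from compound 1 to compound 3 was of the same size a number 16.5 percentage points lower from compound 1 to compound 3 (beyond the scatter), so the two measured departures from the 3-chlorophenyl group both cost a modest amount, while the hydroxy-for-dimethylamino swap on the aromatic carbon made no difference beyond the scatter.

Compound 4 `O=C(N/N=C/c1cccnc1)c1cccnc1Nc1cccc(C(F)(F)F)c1` is not yet measured. It differs from compound 2 as follows: pyridin-3-yl in place of 4-hydroxyphenyl on a carbon with a double bond to nitrogen. Among the compounds with values here, no measured step exchanges the ring itself for a ring with a hetero atom, so the bearing of the known steps is indirect: they say only that the two groups tried in place of 3-chlorophenyl sat close together and below compound 1. A result near compound 2 and compound 3 is therefore expected, with room either way; the step of a number 4.7 percentage points higher from compound 2 to compound 4 (within the scatter) is expected to fall within the scatter. Compound 4 is estimated at 64%, with a range from 50% to 78%.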

Compound 4, a percentage reported as inhibition, in the whole organism at one dose (the size of the read-out at that dose, not a potency): 59.1%
Compound 4: middle estimate off by 4.9 percentage points, on the high side; the range from low to high includes it.
By their numbers in this assay, from the lowest: compounds 4, 2 and 3 (each within the scatter of the next); then compound 1.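

In this assay, a ring with a hetero atom and no hydrogen-bond donor on the carbon with a double bond to nitrogen reads alongside the two substituted phenyl rings: a number 0.2 percentage points lower from compound 2 to compound 4 (within the scatter), and a number 2.2 percentage points lower from compound 3 to compound 4 (within the scatter). At this position, therefore, neither the hydroxy donor of compound 2 nor a carbon-only ring is needed to hold the read-out at this level, and pyridin-3-yl, 4-hydroxyphenyl and 4-(dimethylamino)phenyl form a single cluster, with only the 3-chlorophenyl of compound 1 apart from it, as a number 18.7 percentage points lower from compound 1 to compound 4 (beyond the scatter) adds a third step of similar size to the two already known. No measured evidence is available to explain why these three groups read alike or why 3-chlorophenyl stands apart.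

On these data alone, whether the separation of compound 1 belongs to the chlorine itself or to where it sits on the ring remains open, and 4-chlorophenyl and 3-bromophenyl at this position would bear on that question. Also open, as far as these compounds go, is whether the cluster extends to unsubstituted phenyl or pyridin-4-yl, or breaks with a carboxylic acid on the ring.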